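Morpholin-4-yl for piperidin-1-yl, tested on a second core

The compounds below may be only part of what the source reports. "The series", "measured", "known", "first", "only" and "open" are said of these compounds alone.

Compound 1 `O=C(c1cc(-c2ccc(Cl)cc2)n(-c2ccc(=O)[nH]n2)n1)N1CCCCC1` gives 2090 nM in a functional assay on a cell-free system (Platelet, plasma, Homo sapiens) for inhibition, read by turbidimetry, with a stated time of 3 min; a higher number here means a weaker inhibitor, a lower number a stronger inhibitor.
Compound 2 `O=C(c1cc(-c2ccc(Cl)cc2)n(-c2ccc(=O)[nH]n2)n1)N1CCOCC1` gives 12600 nM in this assay.
Compound 3 `COc1ccc(-n2nc(C(=O)N3CCCCC3)cc2C)nn1` reaches only a limit of the assay, > 10000 nM, in this assay.

Compounds 1 and 2 share one core and differ by morpholin-4-yl in place of piperidin-1-yl on a carbonyl carbon, which produced a 6.0-fold higher number from compound 1 to compound 2 (0.78 log units; beyond the scatter). Compound 4 `COc1ccc(-n2nc(C(=O)N3CCOCC3)cc2C)nn1` has not yet been measured; it differs from compound 3 by the same change, (morpholin-4-yl in place of piperidin-1-yl on a carbonyl carbon), at a place described in the same words. How the core of compound 3 differs from the core of compound 1 is not broken down here. The step expected for compound 4 is a step that the limit leaves unreadable from compound 3 to compound 4, resting on a 6.0-fold higher number from compound 1 to compound 2 (0.78 log units; beyond the scatter) and on compound 3 already standing at the limit of > 10000 nM in this assay, at which 1 of the 3 values shown sits. Compound 4 is therefore expected to give roughly 40000 nM, most probably reported again only as a limit.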

Compound 4, half-maximal inhibitory concentration: > 10000 nM
Compound 4: no number, only a limit; the forecaster's own chance of this, stated with the estimate: 90%; the middle value is on the limit's open side.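

No step can be read from compound 3 to compound 4, since each reaches only a limit: the limit of > 10000 nM in this assay, at which 2 of the 4 values shown sit.

As far as these compounds go, whether morpholin-4-yl in place of piperidin-1-yl shifts the number on the core of compound 3 as it does on the core of compound 1 stays open.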